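A few compounds are considered here, and "the series" means these few. Any claim that something is new, unique, unknown or untested is made for them only; others in the source may bear on it.

Values measured in a functional assay for inhibition, with Homo sapiens as the target; a higher number here means a weaker inhibitor, a lower number a stronger inhibitor:
- Compound 1 `O=C(O)CCNC(=O)c1ccc2c(c1)C(=O)N(CCC1CCNCC1)C2`: 27 nM
- Compound 2 `CS(=O)(=O)N[C@@H](CNC(=O)c1ccc2c(c1)C(=O)N(CCC1CCNCC1)C2)C(=O)O`: 14 nM
- Compound 3 `CCOCCS(=O)(=O)N[C@@H](CNC(=O)c1ccc2c(c1)C(=O)N(CCC1CCNCC1)C2)C(=O)O`: 8 nM

Compound 3 and compound 2 stand together at the low end of these three numbers. The data show a 3.4-fold lower number from compound 1 to compound 3 (0.53 log units; beyond the scatter), whereas they show a 1.8-fold lower number from compound 2 to compound 3 (0.24 log units; within the scatter). The next compound, compound 4 `O=C(NCc1ccccc1)N[C@@H](CNC(=O)c1ccc2c(c1)C(=O)N(CCC1CCNCC1)C2)C(=O)O`, carries benzylcarbamoyl in place of (2-ethoxyethyl)sulfonyl on an amine nitrogen.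

The closest evidence comes from the change on the sulfonyl group, where the data show a 1.8-fold lower number from compound 2 to compound 3 (0.24 log units; within the scatter). The other step that reaches this same amine nitrogen is a 1.9-fold lower number from compound 1 to compound 2 (0.29 log units; within the scatter), and it also stays small. Together these steps show that the measured substituents in this region move the number only slightly. However, none of the measured compounds carries a carbamoyl group on this nitrogen, so the evidence for this exchange is indirect and the range must stay wide. No step beyond the scatter is therefore expected in this assay, and neither direction is favoured with confidence. The estimated step is a 1.4-fold higher number from compound 3 to compound 4 (0.14 log units; within the scatter). Compound 4 is expected at 11 nM, with an estimated range of 4 nM to 30 nM.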

Compound 4, half-maximal inhibitory concentration: 10 nM
Compound 4: middle estimate off by 1.1-fold (0.04 log units), on the high side; low and high end bracket the measured number.
By their numbers in this assay, from the lowest: compounds 3, 4, 2 and 1 (each within the scatter of the next, the first and the last beyond it).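

In this assay, benzylcarbamoyl on the amine nitrogen gives a 1.3-fold higher number from compound 3 to compound 4 (0.10 log units; within the scatter) against (2-ethoxyethyl)sulfonyl and a 1.4-fold lower number from compound 2 to compound 4 (0.15 log units; within the scatter) against methylsulfonyl, so this position is shown for the first time to accept a group without sulfonyl, one that carries a six-membered aromatic ring of carbon only. Set against compound 1, (benzylcarbamoyl)amino gives a 2.7-fold lower number from compound 1 to compound 4 (0.43 log units; beyond the scatter), which makes it the second group after ((2-ethoxyethyl)sulfonyl)amino to stand beyond the scatter from compound 1, while compound 2, with methanesulfonamido, goes against this pattern by staying within it. Nothing in the available data explains why these different groups give such similar numbers.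

The compounds shown leave open what a benzylsulfonyl group or a methylcarbamoyl group on this nitrogen would give, a pair that would separate the contribution of the aromatic ring from that of the carbamoyl link. They also leave open how the number would respond if a methyl ester or a primary amide took the place of the carboxylic acid on this chain.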